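The source may report more compounds than this note shows. Statements on the series, on what has been measured and on what is new or still open speak of the compounds shown alone.

Working notes on the series. Going by the values given here, compound 2 `COc1ccc(-c2ccc3c(c2)oc(=O)n3C(=O)NCCCCc2ccccc2)cc1` and compound 1 `O=C(NCCCCc1ccc2ccccc2c1)n1c(=O)oc2ccccc21` give the two numbers so far. In an assay on HEK293 cells for inhibition of acid ceramidase (Homo sapiens), with a stated time of 10 min (on this read-out higher numbers stand for weaker inhibition and lower numbers for stronger inhibition), compound 2 gives 67 nM, and compound 1 gives 71 nM; the two values lie within the scatter of each other, so no order between them is claimed. The step to compound 3 `Cc1ccc2c(c1)oc(=O)n2C(=O)NCCCCc1ccccc1` brings (methyl in place of 4-methoxyphenyl on an aromatic carbon), methyl in place of 4-methoxyphenyl on an aromatic carbon, on the side of the core meta and para to a fused ring. Among the compounds with values here, no measured pair tells what such a change does here. A modest weakening beyond the scatter in this assay is expected, so that the step of a 2.2-fold higher number from compound 2 to compound 3 (0.35 log units; beyond the scatter) is estimated. Compound 3 is expected to give about 150 nM in this assay, within 40 nM to 600 nM.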

Compound 3, half-maximal inhibitory concentration: 66 nM
Compound 3: the middle estimate sits 2.3-fold (0.36 log units) above what was measured; the range from low to high includes it.
By their numbers in this assay, from the lowest: compounds 3, 2 and 1 (each within the scatter of the next).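

In this assay, methyl in place of 4-methoxyphenyl on this aromatic carbon, meta to a fused ring and para to a fused ring, stays within the scatter (a 1.0-fold lower number from compound 2 to compound 3 (0.01 log units; within the scatter)). The position therefore accepts the loss of an aromatic ring, a hydrogen-bond acceptor and most of the group's heavy atoms without a readable difference. No supporting data bear on why this is so. Going by these compounds, whether an amine or a carboxylic acid on this carbon would also stay within the scatter remains open.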